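A few compounds are considered here, and "the series" means these few. Any claim that something is new, unique, unknown or untested is made for them only; others in the source may bear on it.

For the measured compounds named here, compound 2 `C(=N/Cc1cccnc1)\c1ccccc1` gives 100 mg/kg in a functional assay on the whole organism (strain Swiss albino) with Mus musculus as the target, with a stated time of 0.5 h (a lower number here means that less compound is needed, a higher number that more compound is needed for the effect), the highest of the two numbers measured so far, while compound 1 `O=[N+]([O-])c1ccc(/C=N/Cc2cccnc2)cc1` gives 30 mg/kg. Going by the values given here, the only measured step, a 3.3-fold higher number from compound 1 to compound 2 (0.52 log units; beyond the scatter), is a change at an aromatic carbon of the phenyl ring. Compound 3 `Clc1ccc(/C=N/Cc2cccnc2)cc1` differs from compound 2 by chloro in place of hydrogen on an aromatic carbon. Among the compounds with values here, that step bears on it: a nitro group at that carbon gave the lower number, so a chloro group there is expected to give a modest lower number, though not one as low as that of compound 1, which gives 30 mg/kg, as chloro itself has no measured step. Compound 3 is expected at 50 mg/kg, range 20 mg/kg to 100 mg/kg. The expected step is a 2.0-fold lower number from compound 2 to compound 3 (0.30 log units; within the scatter).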

Compound 3, minimum effective dose: 100 mg/kg
Compound 3: middle estimate off by 2.0-fold (0.30 log units), on the low side; the range from low to high includes it.
By their numbers in this assay, from the lowest: compound 1; then compounds 2 and 3 (each within the scatter of the next).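

In this assay, chloro on the aromatic carbon para to a group of 9 heavy atoms does not separate from hydrogen, with no change at the digits printed from compound 2 to compound 3 (within the scatter) on this change. Nitro at that carbon stands apart from chloro, with a 3.3-fold higher number from compound 1 to compound 3 (0.52 log units; beyond the scatter) on the exchange, so among these three groups only nitro is set apart, and merely filling this carbon is not enough. Nothing available explains why nitro and chloro differ here. Open, from the compounds shown here alone, is how an amine or a methoxy group at this carbon would compare with nitro.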